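Difluorophenyl regioisomers on the benzyloxy substituent of the core

The source may report more compounds than this note shows. Statements on the series, on what has been measured and on what is new or still open speak of the compounds shown alone.

Measured so far in an assay on CHO cells for binding affinity to metabotropic glutamate receptor 2 (Rattus norvegicus); a higher number here means a weaker inhibitor, a lower number a stronger inhibitor:
compound 1 `N[C@]1(C(=O)O)[C@H]2[C@@H](C[C@H]1OCc1ccccc1Cl)[C@]2(F)C(=O)O` gives 4.99 nM
compound 2 `N[C@]1(C(=O)O)[C@H]2[C@@H](C[C@H]1OCc1cc(F)cc(F)c1)[C@]2(F)C(=O)O` gives 12.4 nM

Going by the values given here, compound 2 holds the higher of the two numbers; the only step in hand, a 2.5-fold higher number from compound 1 to compound 2 (0.40 log units; beyond the scatter), separates it from compound 1. Compound 3 `N[C@]1(C(=O)O)[C@H]2[C@@H](C[C@H]1OCc1cccc(F)c1F)[C@]2(F)C(=O)O` differs from compound 2 by 2,3-difluorophenyl in place of 3,5-difluorophenyl on a saturated chain carbon bound to an oxygen on a saturated carbon. That step bears only loosely on the measured one: the step from compound 1 to compound 2 replaces an ortho-chloro aryl by a difluoro aryl, whereas here the two fluorine atoms merely move on the ring. Among the compounds with values here, no measured pair compares two difluorophenyl isomers, so the direction cannot be read from the data; the sole aryl change seen was modest. Compound 3 is therefore expected to stay near compound 2, with an estimated 1.4-fold lower number from compound 2 to compound 3 (0.14 log units; within the scatter) not clearly beyond the scatter, giving an estimated 9 nM in this assay, range 3.5 nM to 25 nM.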

Compound 3, inhibition constant: 4.25 nM
The estimate for compound 3 lay 2.1-fold (0.33 log units) above the measured number; low and high end bracket the measured number.
By their numbers in this assay, from the lowest: compounds 3 and 1 (each within the scatter of the next); then compound 2.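

Where the two fluorine atoms sit on the ring matters at this position in this assay: a 2.9-fold lower number from compound 2 to compound 3 (0.47 log units; beyond the scatter), although the group entering and the group leaving have the same atoms and the same counts. The 2,3-difluorophenyl and 2-chlorophenyl groups are not separated here (a 1.2-fold lower number from compound 1 to compound 3 (0.07 log units; within the scatter)), so a difluorophenyl group is compatible with a number as low as that of the chloro compound, and the higher number of compound 2 belongs to the 3,5-difluorophenyl isomer, not to difluorophenyl groups in general. No evidence at hand bears on the origin of this isomer difference.

Still open, from the compounds shown here alone, is whether the remaining difluorophenyl isomers follow compound 3 or compound 2. Also open, going by these compounds, is how this position responds to a methoxy group on the ring, a pyridine ring in place of the phenyl ring, or a longer chain to the ring.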